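Methylsulfanyl for methoxy on the aryl of compound 2

The compounds below may be only part of what the source reports. "The series", "measured", "known", "first", "only" and "open" are said of these compounds alone.

The series is read in a functional assay on NCI-H727 cells (Homo sapiens), read by fluorescence and BrdU incorporation, with a stated time of 48 h, tested at 25 uM; a lower number here means a stronger effect, a higher number a weaker effect of the compound at the concentration tested. Compound 1 `COc1cc(OC)c(C(=O)/C=C/c2ccccc2SC)c(OC)c1` gives 3%, compound 3 `COc1cc(OC)c(C(=O)/C=C/c2ccc(Cl)cc2)c(OC)c1` gives 0%, and compound 2 `COc1cc(O)c(C(=O)/C=C/c2ccccc2OC)c(OC)c1` gives 14%, the highest of the three numbers, beyond the scatter from both others. Among the measured compounds shown here, the only measured single-point step, a number 3 percentage points lower from compound 1 to compound 3 (within the scatter), concerns an aryl swap and does not touch the change now considered.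

Compound 4 `COc1cc(O)c(C(=O)/C=C/c2ccccc2SC)c(OC)c1` differs from compound 2 by methylsulfanyl in place of methoxy on an aromatic carbon. For the measured compounds named here, no measured pair isolates this change. Compound 1 carries the same methylsulfanyl group but also a methoxy in place of the hydroxy of compound 2, so the value of compound 1, 3%, only shows that a methylsulfanyl-bearing member of the series can sit low. With every number here clustered at weak effect, a step from compound 2 of a number 5 percentage points lower from compound 2 to compound 4 (within the scatter) is expected, small and within the scatter. Compound 4 is therefore estimated at 9%, with a range from 0% to 20%.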

Compound 4, a percentage reported as activity, at one concentration (the size of the read-out at that concentration, not a potency): 12%
The estimate for compound 4 lay 3 percentage points below the measured number; low and high end bracket the measured number.
By their numbers in this assay, from the lowest: compounds 3, 1, 4 and 2 (each within the scatter of the next, the first and the last beyond it).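

In this assay the exchange of methoxy for methylsulfanyl on this aromatic carbon, ortho to a large group, can now be read alone: the pair gives a number 2 percentage points lower from compound 2 to compound 4 (within the scatter) and does not separate the two groups. Compound 4 also opens a second single-point reading, with methylsulfanyl held fixed, of hydrogen in place of methyl on an oxygen on the aromatic ring: a number 9 percentage points higher from compound 1 to compound 4 (within the scatter) and so no separation at that oxygen either. No measured property or other outside data bears on these two results, and no cause can be assigned to them.

The compounds shown leave open whether an amine or a carboxylic acid on this aromatic carbon would move the number beyond the scatter. They also leave open whether a longer chain on the sulfur, such as ethylsulfanyl, would do so.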